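This account rests on a few compounds, and the source may have more. Where it says the series, first, only, none or still open, it means among the compounds named here.

Measured compounds in an ADME assay on THP-1 cells (Homo sapiens) for cytotoxicity; a higher number here means a weaker inhibitor, a lower number a stronger inhibitor:
compound 1 `COc1ccccc1-c1nnc(-c2ccc(C(=O)N/N=C/c3ccccc3[N+](=O)[O-])cc2)o1` gives 161000 nM
compound 2 `COc1ccccc1-c1nnc(-c2ccc(C(=O)N/N=C/c3ccccc3O)cc2)o1` gives 207000 nM

Among the compounds with values here, of the two numbers in this assay, compound 2 stands at the higher one; its nearest neighbour is compound 1, and the single measured step of a 1.3-fold higher number from compound 1 to compound 2 (0.11 log units; within the scatter) is within the scatter, so the two compounds cannot be ordered on this basis.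

Compound 3 `COc1ccccc1-c1nnc(-c2ccc(C(=O)N/N=C/c3ccncc3)cc2)o1` is not yet measured. It differs from compound 2 in one place: pyridin-4-yl in place of 2-hydroxyphenyl on a carbon with a double bond to nitrogen. Within the data shown here, the only measured step, a 1.3-fold higher number from compound 1 to compound 2 (0.11 log units; within the scatter), concerns the same carbon with a double bond to nitrogen and exchanges one group there for another without moving the number beyond the scatter. Among the measured compounds shown here, no measured step involves a pyridin-4-yl group, so nothing in the numbers so far points to a shift in either direction for this exchange. The expectation for compound 3 in this assay is therefore a step of about a 1.1-fold lower number from compound 2 to compound 3 (0.04 log units; within the scatter), that is, none beyond the scatter.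

The estimate for compound 3 in this assay is 190000 nM, with a range from 90000 nM to 400000 nM.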

Compound 3, half-maximal inhibitory concentration: 173000 nM
Estimate against measurement, compound 3: 1.1-fold (0.04 log units) above; the measured number falls inside the stated range.
By their numbers in this assay, from the lowest: compounds 1, 3 and 2 (each within the scatter of the next).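

In this assay, the carbon with a double bond to nitrogen now has a third group, and the first with a hetero atom in its six-membered aromatic ring. Neither step to pyridin-4-yl leaves the scatter: a 1.2-fold lower number from compound 2 to compound 3 (0.08 log units; within the scatter) for the exchange with 2-hydroxyphenyl, and a 1.1-fold higher number from compound 1 to compound 3 (0.03 log units; within the scatter) for the exchange with 2-nitrophenyl. The number at this place therefore stays within the scatter across a ring nitrogen and the loss of the hydrogen-bond donor of 2-hydroxyphenyl, and compounds 1, 2 and 3 cannot be ordered; no supporting data bear on this result.

From the compounds shown here alone, all three groups at this place are six-membered aromatic rings, so it remains open whether a saturated piperidine ring, a longer alkyl chain, an amine or a carboxylic acid there would move the number beyond the scatter. The core is also the same in all three compounds, which leaves open what any change elsewhere in it would do.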